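Swapping a sulfonyl aryl group on a shared core

This account rests on a few compounds, and the source may have more. Where it says the series, first, only, none or still open, it means among the compounds named here.

Measured so far:
compound 1 `COc1ccc(S(=O)(=O)N2CCN(c3nc(N)c4cc(OC)c(OC)cc4n3)CC2)cc1`: 39000 nM
compound 2 `COc1cc2nc(N3CCN(S(=O)(=O)c4ccc(OC(F)(F)F)cc4)CC3)nc(N)c2cc1OC`: 25000 nM

Compound 1 and compound 2 share one core and differ only in the group on an oxygen of the aryl ring that sits on the sulfonyl sulfur. In a functional assay on PC-3 cells (Homo sapiens) for inhibition (a lower number here means a stronger inhibitor, a higher number a weaker inhibitor), compound 1 gives 39000 nM, and compound 2 gives 25000 nM. The step of a 1.6-fold lower number from compound 1 to compound 2 (0.19 log units; within the scatter) is therefore not a real change; compound 2 holds the lowest of the two numbers, but only within the scatter of compound 1.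

Compound 3 `COc1cc2nc(N3CCN(S(=O)(=O)c4cccc(C(=O)O)c4)CC3)nc(N)c2cc1OC` is the unmeasured member. It differs from compound 2 in one place: 3-carboxyphenyl in place of 4-(trifluoromethoxy)phenyl on a sulfonyl sulfur. Among the measured compounds shown here, the only measured step, a 1.6-fold lower number from compound 1 to compound 2 (0.19 log units; within the scatter), concerns a much smaller change on the same aryl group and gave no movement beyond the scatter; it says little about replacing the whole aryl group with one carrying a carboxylic acid. With no closer comparison available, the expectation for compound 3 in this assay is a number near that of compound 2, with a wide range to allow for a shift in either direction: 30000 nM (8000 nM to 150000 nM), an expected step of a 1.2-fold higher number from compound 2 to compound 3 (0.08 log units; within the scatter).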

Compound 3, half-maximal inhibitory concentration: 53000 nM
Estimate against measurement, compound 3: 1.8-fold (0.25 log units) below; measured number inside the range.
By their numbers in this assay, from the lowest: compounds 2, 1 and 3 (each within the scatter of the next, the first and the last beyond it).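

Among the compounds shown here, exchanging the whole aryl group on the sulfonyl sulfur, rather than only a small part of it, gives the first step at this position in this assay that passes the usual scatter: a 2.1-fold higher number from compound 2 to compound 3 (0.33 log units; beyond the scatter) is a modest step. The comparison with the 4-methoxyphenyl group remains within the scatter at a 1.4-fold higher number from compound 1 to compound 3 (0.13 log units; within the scatter) and so shows no real difference, which means that 3-carboxyphenyl is separated from only one of the two aryl groups measured before it. No measurement is available to explain the difference between the 3-carboxyphenyl and 4-(trifluoromethoxy)phenyl compounds.

From the compounds shown here alone, all three compounds carry an aryl group on the sulfonyl sulfur, so the effect of a short alkyl chain or a benzyl group there remains open, as does whether any group at this position can bring the number far below those seen so far. Going by these compounds, it also remains open whether the carboxylic acid itself matters, a question that a methyl ester or an amide in its place could address.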